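Oxazole for methylpyridine at the ether-bearing chain carbon

The compounds below may be only part of what the source reports. "The series", "measured", "known", "first", "only" and "open" are said of these compounds alone.

Compound 1 `Cc1ccc([C@@H](C)Oc2cc3oc(=O)n(CCC(=O)O)c3cc2Cl)nc1` sits second highest of the three numbers measured in an assay on HEK293 cells for inhibition of kynurenine 3-monooxygenase (Homo sapiens), read by LC-MS, with a stated time of 20 h (a higher number here means a weaker inhibitor, a lower number a stronger inhibitor), giving 6.31 nM. Its nearest neighbour is compound 3 `C[C@@H](Oc1cc2onc(CCC(=O)O)c2cc1Cl)c1ccc(Cl)cn1`, which in this assay gives 3.98 nM; the two values lie within the scatter, so no order between them is claimed. The furthest is compound 2 `O=C(O)CCn1c(=O)oc2cc(OCC3CC3)c(Cl)cc21`, which carries a cyclopropylmethyl ether in place of the aryl-bearing chain and gives 1580 nM in this assay, a gap well beyond the scatter.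

Compound 4 `C[C@@H](Oc1cc2oc(=O)n(CCC(=O)O)c2cc1Cl)c1ncco1` is not yet measured. It differs from compound 1 in one place: 1,3-oxazol-2-yl in place of 5-methylpyridin-2-yl on a saturated chain carbon bound to an oxygen on an aromatic ring and a saturated chain carbon. For the measured compounds named here, no step between measured compounds isolates this change. What the measured values show is that compound 1 and compound 3, each with a six-membered aromatic ring on that chain carbon, sit at the low end, while compound 2, with no aromatic ring there, sits far higher. Going by the values given here, a five-membered aromatic ring is an intermediate case with no direct precedent.

The expectation for compound 4 is a weakening relative to compound 1, of moderate size and probably beyond the scatter, expressed as a 4.8-fold higher number from compound 1 to compound 4 (0.68 log units; beyond the scatter). The estimated value for compound 4 in this assay is 30 nM, with a range from 8 nM to 150 nM.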

Compound 4, half-maximal inhibitory concentration: 7940 nM
For compound 4 the middle estimate is 260-fold (2.42 log units) below the measured one; the whole stated range lies below it.
By their numbers in this assay, from the lowest: compounds 3 and 1 (each within the scatter of the next); then compound 2; then compound 4.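

In this assay, 1,3-oxazol-2-yl in place of 5-methylpyridin-2-yl on the saturated chain carbon gives a 1300-fold higher number from compound 1 to compound 4 (3.10 log units; beyond the scatter), so this position does not treat these two aromatic rings as interchangeable. The step to the ether without an aromatic ring is also informative: the change gives a 5.0-fold higher number from compound 2 to compound 4 (0.70 log units; beyond the scatter), so the earlier picture of aromatic rings at the low end and their absence at the high end no longer holds, with compound 4 going against it. No measurement at hand accounts for either step.

The change combines ring size, hetero atom count and loss of the methyl, and these remain unseparated here: a pyridin-2-yl without the methyl, a phenyl, a 1,3-thiazol-2-yl or a 5-methyl-1,3-oxazol-2-yl on the same chain carbon would begin to divide them. Going by these compounds, whether the 1,3-oxazol-2-yl has a comparable effect on the core of compound 3 also remains open.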